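Extending the Chain and Swapping the Headgroup Together

The source may report more compounds than this note shows. Statements on the series, on what has been measured and on what is new or still open speak of the compounds shown alone.

Compound 3, `C/N=C(/NC#N)NCCCn1nc(-c2ccccc2)ccc1=O`, stands at the threshold of a functional assay on the whole organism (stomach) with Rattus norvegicus as the target; a lower number here means that less compound is needed, a higher number that more compound is needed for the effect: in this assay compound 3 gives > 100 mg/kg, which is a limit of the measurement rather than a number. Compound 2, `CC/N=C(\S)NCCCn1nc(-c2ccccc2)ccc1=O`, also ends at a limit, giving > 100 mg/kg in this assay. Going by the values given here, the one step that links these two, a step that the two limits leave unreadable from compound 2 to compound 3, therefore cannot be read in size or direction. Among the compounds with values here, the only full number comes from compound 1, `CC/N=C(/NC#N)NCCCCn1nc(-c2ccccc2)ccc1=O`, which in this assay gives 92 mg/kg; no single step joins compound 1 to compound 3 or compound 4, so its value can only serve as a reference point.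

Compound 4, `CC/N=C(\S)NCCCCn1nc(-c2ccccc2)ccc1=O`, is reached from compound 3 by a group of 7 heavy atoms (4 carbon, 2 nitrogen, 1 sulfur; no ring) in place of a group of 7 heavy atoms (3 carbon, 4 nitrogen; no ring), on a saturated chain carbon, three bonds along the chain from an aromatic nitrogen. Within the data shown here, no measured step covers this change. What the numbers do show is summarized by the limit of > 100 mg/kg in this assay, at which 2 of the 3 values shown sit, and compound 2, which shares the thiourea headgroup with compound 4, sits at that limit. Given this, compound 4 is expected to land near the limit as well, with the step that the limit leaves unreadable from compound 3 to compound 4 estimated as small. The expected value for compound 4 in this assay is 130 mg/kg, within a range from 60 mg/kg to 300 mg/kg.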

Compound 4, dose for half-maximal effect: 37.2 mg/kg
Estimate against measurement, compound 4: 3.5-fold (0.54 log units) above; the whole stated range lies above it.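

With the sulfur-bearing headgroup kept in place, the longer chain of compound 4 gives an at least 2.6-fold lower number from compound 2 to compound 4 (0.42 log units; beyond the scatter) in this assay, so this saturated chain carbon is now a place where a change can move the read-out clear of the assay limit. The step that alters both chain and headgroup gives an at least 2.6-fold lower number from compound 3 to compound 4 (0.42 log units; beyond the scatter) as well, and this size, like the one before it, is only a bound, since the starting value of each step is a limit and not a number: the limit of > 100 mg/kg in this assay, at which 2 of the 4 values shown sit.

Going by these compounds alone, the only step with two full numbers holds the chain fixed and swaps the headgroup on the amine nitrogen, and it gives a 2.5-fold lower number from compound 1 to compound 4 (0.39 log units; beyond the scatter) in this comparison, which shows that the headgroup matters as well as the chain, although the step is modest.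

Going by these compounds, the true sizes of the two bounded steps remain unknown, and the step between the two shorter-chain compounds still cannot be read. On these data alone, whether a still longer chain would lower the dose further, or whether a urea or an amine in place of the sulfur-bearing headgroup would keep the gain, remains open.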